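Fluoro to hydroxy on the fused ring of compound 3

The source may hold more compounds than are shown below. What is called first, only, known or untested is meant among the compounds shown, and "the series" means these compounds.

Compound 1 `COc1ccc2c(c1)CCC(NC[C@H]1CC[C@H](CNS(=O)(=O)c3ccc4ccccc4c3)CC1)C2Cc1ccccc1`: 443 nM
Compound 2 `O=S(=O)(NC[C@H]1CC[C@H](CNC2CCc3cc(F)ccc3C2Cc2cccnc2)CC1)c1ccccc1`: 27 nM
Compound 3 `O=S(=O)(NC[C@H]1CC[C@H](CNC2CCc3cc(F)ccc3C2Cc2cccnc2)CC1)c1ccccc1F`: 19 nM

In an assay on HEK293 cells for binding affinity to Neuropeptide Y receptor type 5 (Homo sapiens) (on this read-out lower numbers stand for stronger inhibition and higher numbers for weaker inhibition), compound 3 gives 19 nM, and compound 2 gives 27 nM, so the two sit within the scatter of each other. Compound 1, with its different aryl groups and a methoxy on the fused ring, gives 443 nM, well apart from both. Among the measured compounds shown here, the one single-point step on record, a 1.4-fold lower number from compound 2 to compound 3 (0.15 log units; within the scatter), shows that putting fluoro onto this aromatic carbon hardly moves the number.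

Compound 4 `O=S(=O)(NC[C@H]1CC[C@H](CNC2CCc3cc(O)ccc3C2Cc2cccnc2)CC1)c1ccccc1F` is not yet measured. It differs from compound 3 by hydroxy in place of fluoro on an aromatic carbon. For the measured compounds named here, no measured pair swaps fluoro for hydroxy, and compound 1 carries its methoxy alongside other changes, so it gives no clean guide. Going by the values given here, with the only relevant step being small, compound 4 is expected to stay close to compound 3, with the estimate leaning towards a modest rise, a 2.1-fold higher number from compound 3 to compound 4 (0.32 log units; beyond the scatter). The estimated value for compound 4 in this assay is 40 nM, within a range of 10 nM to 160 nM.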

Compound 4, half-maximal inhibitory concentration: 7 nM
Compound 4: the middle estimate sits 5.7-fold (0.76 log units) above what was measured; the measured number lies below the stated range.
By their numbers in this assay, from the lowest: compound 4; then compounds 3 and 2 (each within the scatter of the next); then compound 1.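

In this assay, hydroxy in place of fluoro gives a 2.7-fold lower number from compound 3 to compound 4 (0.43 log units; beyond the scatter), a modest step but one beyond the scatter. Among the compounds shown here, this is the first single change at this aromatic carbon, since the earlier step, a 1.4-fold lower number from compound 2 to compound 3 (0.15 log units; within the scatter), lay on a different ring and stayed within the scatter, so the number responds to what sits at this position, and a group with one hydrogen-bond donor and one hydrogen-bond acceptor is accepted there. Nothing on record bears on why the number fell.

As far as these compounds go, it remains open whether the lower number belongs to hydroxy specifically, or whether an amine or a carboxylic acid at this carbon would match it. Compound 1 carries a methoxy with other changes, so how methoxy behaves on the core of compound 4 also stays unsettled.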